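This account rests on a few compounds, and the source may have more. Where it says the series, first, only, none or still open, it means among the compounds named here.

The series shares one core. Compound 1 `CCn1c([C@@H](C)NS(=O)(=O)c2ccc(Cl)cc2)nc2ccc(C(F)(F)F)cc21` is the starting point. In an ADME assay (liver) for metabolic stability, with Liver microsome (Homo sapiens) as the target, read by LC-MS, using microsomes and NADPH, with a stated time of 5 min, at 37 degrees C (on this read-out higher numbers stand for fast clearance and lower numbers for slow clearance), compound 1 gives a result that is a limit of the assay, > 100 mL.min-1.g-1, one of the values sitting at the limit of > 100 mL.min-1.g-1 in this assay, at which 1 of the 3 values shown sits. Compound 2 `CCn1c([C@@H](C)NS(=O)(=O)c2ccc(Cl)cc2)nc2cc(C#N)ccc21` carries a cyano group on the core; in this assay compound 2 gives 71 mL.min-1.g-1. Compound 3 `CCn1c([C@@H](C)NS(=O)(=O)c2ccc(Cl)cc2)nc2cc(C(N)=O)ccc21` carries a carbamoyl group in its place. For compound 3 the result in this assay is a limit of the assay, < 5 mL.min-1.g-1, sitting at the limit of < 5 mL.min-1.g-1 in this assay, at which 1 of the 3 values shown sits. Within the data shown here, the only measured step, an at least 14-fold lower number from compound 2 to compound 3 (1.15 log units; beyond the scatter), concerns the substituent on the core and not the sulfonyl side of the molecule. Compound 4 `CCCn1ncc(S(=O)(=O)N[C@H](C)c2nc3ccc(C(F)(F)F)cc3n2CC)c1C` differs from compound 1 at that other position: 5-methyl-1-propyl-1H-pyrazol-4-yl in place of 4-chlorophenyl on a sulfonyl sulfur. Among the measured compounds shown here, no measured step covers a change on the sulfonyl sulfur, so no direction can be read from the values shown for such a change. Compound 1 stands at the upper limit of the assay. Compound 4 is expected to remain in the same high region, with an estimated step of an at least 1.2-fold lower number from compound 1 to compound 4 (0.09 log units; that floor lies within the scatter). The estimate for compound 4 is 80 mL.min-1.g-1, with a range from 30 mL.min-1.g-1 to 150 mL.min-1.g-1, and a fair chance that only a limit is reported again.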

Compound 4, intrinsic clearance in microsomes: > 100 mL.min-1.g-1
Compound 4: only a limit was reported; the forecaster's own chance of this, stated with the estimate: 40%; middle value at least 1.2-fold (0.09 log units) from the limit.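

In this assay compound 4 gives > 100 mL.min-1.g-1 as a limit of the assay. Among these compounds, compound 1 sits at the same limit, so no step between compound 1 and compound 4 can be read. Going by these compounds, whether 5-methyl-1-propyl-1H-pyrazol-4-yl in place of 4-chlorophenyl on a sulfonyl sulfur changes the clearance at all remains open.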